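The source may report more compounds than this note shows. Statements on the series, on what has been measured and on what is new or still open speak of the compounds shown alone.

Measured so far in an ADME assay on Vero cells (Chlorocebus sabaeus) for cytotoxicity; on this read-out higher numbers stand for lower toxicity in this test and lower numbers for higher toxicity in this test: compound 1 `O=C(Nc1ccccc1)c1cccc2[nH]c(-c3ccccn3)nc12` gives 17.9 uM; compound 2 `O=C(Nc1ccccc1F)c1cccc2[nH]c(-c3ccccn3)nc12` gives 54.7 uM; compound 3 `Cc1csc(NC(=O)c2cccc3[nH]c(-c4ccccn4)nc23)n1` gives 17.7 uM.

Compound 2 holds the highest of these three numbers, that is, the lowest toxicity measured here. The step of a 3.1-fold higher number from compound 1 to compound 2 (0.49 log units; beyond the scatter) and the step of a 3.1-fold lower number from compound 2 to compound 3 (0.49 log units; beyond the scatter) both set it apart from the other two, while a 1.0-fold lower number from compound 1 to compound 3 (0.00 log units; within the scatter) shows compound 1 and compound 3 at the same level.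

Compound 4 `O=C(Nc1ccccc1F)c1cccc2[nH]c(-c3ccco3)nc12` is made from compound 2 by one change: furan-2-yl in place of pyridin-2-yl on an aromatic carbon. None of the three measured steps bears directly on this, since every one of them alters only the group on the amide-type nitrogen and leaves the pyridin-2-yl group on the shared core untouched. There is therefore no measured guide for swapping one small aromatic ring for another at this position, and the expectation is a step of no size beyond the scatter in this assay, in either direction.

Compound 4 is accordingly estimated at 40 uM, with a range from 15 uM to 110 uM, which corresponds to an expected step of a 1.4-fold lower number from compound 2 to compound 4 (0.14 log units; within the scatter).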

Compound 4, half-maximal toxic concentration: 25 uM
Compound 4: the middle estimate sits 1.6-fold (0.20 log units) above what was measured, and the stated range covers the measured number.
By their numbers in this assay, from the lowest: compounds 3, 1 and 4 (each within the scatter of the next); then compound 2.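

Swapping pyridin-2-yl for furan-2-yl on the aromatic carbon between two ring nitrogen atoms gives a 2.2-fold lower number from compound 2 to compound 4 (0.34 log units; beyond the scatter) in this assay, and this lower number stands for higher toxicity in this test. Among these compounds, the earlier steps changed only the group on the amide-type nitrogen, as in a 3.1-fold higher number from compound 1 to compound 2 (0.49 log units; beyond the scatter), so this is the first sign that the read-out also responds to a change at this other place on the shared core. No measurement at hand accounts for this step.

The compounds shown leave open what a phenyl, a thiophen-2-yl or an amine would give at this place. On these data alone, it is also open whether the same swap gives a similar step when the amide-type nitrogen carries phenyl or 4-methyl-1,3-thiazol-2-yl rather than 2-fluorophenyl.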